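The source may report more compounds than this note shows. Statements on the series, on what has been measured and on what is new or still open speak of the compounds shown alone.

Compound 1 `Clc1cccc(-c2cc(-c3ccoc3)cc(-c3ccc(Cl)s3)n2)c1`, compound 2 `Clc1ccc(-c2cc(-c3ccoc3)cc(-c3ccc(Cl)s3)n2)cc1` and compound 3 `Clc1cccc(-c2cc(-c3ccc(Cl)o3)cc(-c3ccc(Cl)s3)n2)c1` share one core and were tested in an assay on isolated protein for inhibition of DNA topoisomerase 1 (Homo sapiens), with a stated time of 30 min, tested at 100 uM; a lower number here means less inhibition, a higher number more inhibition at the concentration tested (going by the name of the read-out). Compound 1 gives 2.1%, compound 2 gives 2.3% and compound 3 gives 13.3%. The change 4-chlorophenyl in place of 3-chlorophenyl on an aromatic carbon produced a number 0.2 percentage points higher from compound 1 to compound 2 (within the scatter). The change 5-chlorofuran-2-yl in place of furan-3-yl on an aromatic carbon produced a number 11.2 percentage points higher from compound 1 to compound 3 (beyond the scatter). Compound 4 `Clc1ccc(-c2cc(-c3ccc(Cl)o3)cc(-c3ccc(Cl)s3)n2)cc1` has not yet been measured; it differs from compound 3 by 4-chlorophenyl in place of 3-chlorophenyl on an aromatic carbon. Going by the values given here, this is the same kind of change as the one from compound 1 to compound 2, though the surroundings differ: there the place was meta to a furan-3-yl group (5 heavy atoms), here it is meta to a 5-chlorofuran-2-yl group (6 heavy atoms). Because a number 0.2 percentage points higher from compound 1 to compound 2 (within the scatter) stayed within the scatter, a similarly small step is expected here. The expected step is a number 0.2 percentage points higher from compound 3 to compound 4 (within the scatter). Compound 4 is therefore estimated at 13.5%, with a likely range from 5% to 22%.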

Compound 4, a percentage reported as inhibition, at one concentration (the size of the read-out at that concentration, not a potency): 2.2%
Compound 4: the middle estimate sits 11.3 percentage points above what was measured; the whole stated range lies above it.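

The change to 4-chlorophenyl in place of 3-chlorophenyl gave a number 11.1 percentage points lower from compound 3 to compound 4 (beyond the scatter), yet this step cannot be told apart from the same change on the other core: the same change on two cores in this assay, a number 0.2 percentage points higher (within the scatter) from compound 1 to compound 2 and a number 11.1 percentage points lower (beyond the scatter) from compound 3 to compound 4, 11.3 percentage points apart, within the scatter of two such steps

The change to 5-chlorofuran-2-yl in place of furan-3-yl gave a number 0.1 percentage points lower from compound 2 to compound 4 (within the scatter), and it likewise cannot be told apart from its earlier step: the same change on two cores in this assay, a number 11.2 percentage points higher (beyond the scatter) from compound 1 to compound 3 and a number 0.1 percentage points lower (within the scatter) from compound 2 to compound 4, 11.3 percentage points apart, within the scatter of two such steps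

Going by these compounds alone, neither comparison shows that a change carries over between cores or that it fails to, and both rest on a single reading, the one for compound 3 at 13.3%.

Still open, from the compounds shown here alone, is whether a different group, such as an amine or a carboxylic acid on the phenyl ring in place of the chlorine, would give clearly more inhibition.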